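A few compounds are considered here, and "the series" means these few. Any claim that something is new, unique, unknown or untested is made for them only; others in the source may bear on it.

Compound 1 `COc1ccc(F)cc1CNCCCNc1ccnc2cc(C3CCCCC3)ccc12` was examined in a physicochemical assay for solubility, with a stated time of 18 h, at pH 7.4 (on this read-out higher numbers stand for higher solubility and lower numbers for lower solubility), where compound 1 gives 4200 nM. Compound 3 `c1coc(CNCCCNc2ccnc3cc(C4CCCCC4)ccc23)c1` gives 4200 nM in this assay, and compound 2 `COc1cccc(CNCCCNc2ccnc3cc(Oc4cccc(N(C)C)c4)ccc23)c1O` gives 14500 nM. Compound 1 thus sits level with compound 3, the two together the lowest of the three numbers, while compound 2 stands higher by an amount beyond the scatter. Among the measured compounds shown here, the one step recorded between measured compounds, no change at the digits printed from compound 1 to compound 3 (within the scatter), exchanges furan-2-yl for 5-fluoro-2-methoxyphenyl on a saturated chain carbon bound to an amine nitrogen and leaves the read-out where it was.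

Compound 4 `COc1ccc(F)cc1CNCCCNc1ccnc2cc(Oc3ccccc3OC)ccc12` differs from compound 1 in another place: 2-methoxyphenoxy in place of cyclohexyl on an aromatic carbon. For the measured compounds named here, no measured step covers this exact exchange. Compound 2 carries an aryloxy group at the same kind of position and differs from compound 1 elsewhere as well, and compound 2 shows the higher value 14500 nM. On that basis compound 4 is expected to move upward by a 1.9-fold higher number from compound 1 to compound 4 (0.28 log units; within the scatter), a shift of modest size. For compound 4 the estimate in this assay is 8000 nM, with a range from 3000 nM to 22000 nM.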

Compound 4, solubility: 14500 nM
For compound 4 the middle estimate is 1.8-fold (0.26 log units) below the measured one; low and high end bracket the measured number.
By their numbers in this assay, from the lowest: compounds 1 and 3 (each within the scatter of the next); then compounds 2 and 4 (each within the scatter of the next).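

On the aromatic carbon, 2-methoxyphenoxy in place of cyclohexyl gives a 3.5-fold higher number from compound 1 to compound 4 (0.54 log units; beyond the scatter) in this assay, whereas the exchange on the saturated chain carbon gave no change at the digits printed from compound 1 to compound 3 (within the scatter) and left the number where it stood. This position is therefore the one place among the compounds shown where a single exchange has moved the read-out beyond the scatter. No measurement offered here accounts for this step.

The exchange replaces a non-aromatic ring of carbon only with an aromatic ring, attached through oxygen and carrying a methoxy group, and the compounds shown do not separate these features. Plain phenoxy, phenyl or a piperidine on the same aromatic carbon would each test one of these changes, and it remains open which of them carries the step.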